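Trichlorophenyl Sulfonamide Analogue of an Inactive Series

The source may report more compounds than this note shows. Statements on the series, on what has been measured and on what is new or still open speak of the compounds shown alone.

Measured compounds:
compound 1 `COc1ccc(S(=O)(=O)NC2=NCCN2C(=S)SN2CCn3c2nsc3=S)cc1`: >= 20000 nM
compound 2 `CC(=O)Nc1ccc(S(=O)(=O)NC2=NCCN2C(=S)SN2CCn3c2nsc3=S)cc1`: >= 20000 nM
compound 3 `O=S(=O)(NC1=NCCN1C(=S)SN1CCn2c1nsc2=S)c1cc(Cl)cc(Cl)c1`: >= 20000 nM

In a functional assay on KYSE-510 cells (Homo sapiens) for antiproliferative activity, read by crystal violet staining, with a stated time of 96 h (on this read-out lower numbers stand for stronger inhibition of growth and higher numbers for weaker inhibition of growth), compound 1 gives only a limit, >= 20000 nM, and not a number. Compound 2 also gives only a limit, >= 20000 nM. Compound 3 likewise gives only a limit, >= 20000 nM. The steps a step that the two limits leave unreadable from compound 1 to compound 2, a step that the two limits leave unreadable from compound 1 to compound 3 and a step that the two limits leave unreadable from compound 2 to compound 3 are therefore not readable, since all three values sit at the same limit (the limit of >= 20000 nM in this assay, at which 3 of the 3 values shown sit).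

Compound 4 `O=S(=O)(NC1=NCCN1C(=S)SN1CCn2c1nsc2=S)c1ccc(Cl)c(Cl)c1Cl` differs from compound 1 by 2,3,4-trichlorophenyl in place of 4-methoxyphenyl on a sulfonyl sulfur. The closest measured change is the step that the two limits leave unreadable from compound 1 to compound 3, which swaps the 4-methoxyphenyl for another chlorinated phenyl; its size is hidden by the limit, so no direction can be read from it. With every measured value at the limit, the expectation for compound 4 in this assay is that it too falls at or beyond the limit, and the estimated step of a number no higher from compound 1 to compound 4 (the limit leaves the size open) is expected to show no readable size. Compound 4 is thus estimated at 20000 nM, with a range from 10000 nM to 40000 nM.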

Compound 4, concentration for 50% growth inhibition: >= 20000 nM
Compound 4 was reported as a limit; the forecaster's own chance of this, stated with the estimate: 85%; the middle value lies on the limit itself.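

Compound 4, like compound 1, compound 2 and compound 3, gives only a limit, so none of its steps to those three compounds can be read: the limit of >= 20000 nM in this assay, at which 4 of the 4 values shown sit. In this assay the compounds shown leave open whether the groups on the sulfonyl sulfur differ at all in their inhibition of growth.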